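Extending the alkyl chain on a platelet-activating factor antagonist scaffold

The compounds below may be only part of what the source reports. "The series", "measured", "known", "first", "only" and "open" are said of these compounds alone.

The two measured compounds and their values:

compound 1, `CCC/C(=C\C=C\C(=O)N[C@H](C)CCCc1cccnc1)c1ccc(OC)cc1`: 0.52 mg/kg
compound 2, `O=C(/C=C/C=C(c1ccc(F)cc1)c1ccc(F)cc1)NCCCCc1cccnc1`: 0.38 mg/kg

Both compounds were characterised in a functional assay with platelet-activating factor receptor (Cavia porcellus) as the target; on this read-out lower numbers stand for an effect already at smaller amounts and higher numbers for an effect only at larger amounts of compound. Compound 1 gives 0.52 mg/kg, which is the higher of the two numbers recorded, while compound 2 gives 0.38 mg/kg; the gap between them is within the usual scatter of repeated measurements, so the two compounds are treated as indistinguishable on this read-out.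

The unmeasured compound 3, `CCCCCCCC/C(=C\C=C\C(=O)N[C@H](C)CCCc1cccnc1)c1ccc(OC)cc1`, is obtained from compound 1 by a single change: pentyl in place of hydrogen on a saturated chain carbon, three bonds along the chain from a double-bonded chain carbon. Cut one bond further out, the same difference reads propyl to octyl, so the saturated chain on the diene is lengthened considerably while the methoxyphenyl group, the dienamide and the pyridine-bearing side chain of compound 1 are kept.

Within the data shown here, no step between measured compounds describes such a chain extension, so the direction of the change in this assay rests on no measured precedent here. The account expects at most a modest shift for the step of a 1.3-fold higher number from compound 1 to compound 3 (0.13 log units; within the scatter), possibly none beyond the scatter. Compound 3 is therefore estimated at 0.7 mg/kg, with a range from 0.25 mg/kg to 2 mg/kg.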

Compound 3, dose for 50% inhibition: 0.1 mg/kg
For compound 3 the middle estimate is 7.0-fold (0.85 log units) above the measured one, outside the stated range (below it).
By their numbers in this assay, from the lowest: compound 3; then compounds 2 and 1 (each within the scatter of the next).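

In this assay, the saturated chain on the diene turns out to be a place where the read-out responds: pentyl in place of hydrogen on a saturated chain carbon, three bonds along the chain from a double-bonded chain carbon, gives a 5.2-fold lower number from compound 1 to compound 3 (0.72 log units; beyond the scatter) and so moves the number beyond the scatter. The two earlier compounds differed in several places at once and could tie no change in the number to this position, whereas here a single change, reading propyl to octyl when cut one bond further out, goes with a lower number while the methoxyphenyl group, the dienamide and the pyridine-bearing side chain stay as they were. Nothing measured here explains the step.

Propyl and octyl are the only chain lengths shown at this place, so it remains open whether the number falls steadily with length, levels off or turns back, as a hexyl chain or a dodecyl chain would show. On these data alone, it is also open whether the chain has to be a plain hydrocarbon, or whether an octyl chain ending in a carboxylic acid or an amine would give a similar number.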